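The source may report more compounds than this note shows. Statements on the series, on what has been measured and on what is new or still open speak of the compounds shown alone.

Series so far, read in an ADME assay (liver) for metabolic stability, with Liver microsome (Homo sapiens) as the target, using microsomes and NADPH, with a stated time of 30 min, tested at 1 uM (a higher number here means faster removal of the compound, a lower number slower removal), for each compound
- compound 1 `Nc1ccc(S(=O)(=O)N2CCN(c3ncc(C(O)(C(F)(F)F)C(F)(F)F)cc3-c3ccccc3O)CC2)cn1` gives 22 mL.min-1.g-1
- compound 2 `Nc1ccc(S(=O)(=O)N2CCN(c3ncc(C(O)(C(F)(F)F)C(F)(F)F)cc3-c3ccncc3)CC2)cn1` gives 15 mL.min-1.g-1
- compound 3 `Nc1ccc(S(=O)(=O)N2CCN(c3ncc(C(O)(C(F)(F)F)C(F)(F)F)cc3-c3cccnc3)CC2)cn1` gives 17 mL.min-1.g-1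

Compound 3 at 17 mL.min-1.g-1 lies within the scatter of both other compounds. The next change leads to compound 4 `Nc1ccc(S(=O)(=O)N2CCN(c3ncc(C(O)(C(F)(F)F)C(F)(F)F)cc3-c3ccc4sccc4c3)CC2)cn1` and is 1-benzothiophen-5-yl in place of pyridin-3-yl on an aromatic carbon. Within the data shown here, the steps that bear on it are the swaps on that same aromatic carbon: a 1.5-fold lower number from compound 1 to compound 2 (0.17 log units; within the scatter), a 1.3-fold lower number from compound 1 to compound 3 (0.11 log units; within the scatter) and a 1.1-fold higher number from compound 2 to compound 3 (0.05 log units; within the scatter). Among the measured compounds shown here, all three stay within the scatter, so exchanging these groups has not measurably moved this assay so far. None of them brings in a 1-benzothiophen-5-yl group, which makes them a weak guide here. Nothing measured gives the direction, and an upward move is only a judgement on the change itself. The expected move is modest, with a wide margin, and the estimated step is a 1.8-fold higher number from compound 3 to compound 4 (0.25 log units; within the scatter) in this series. For compound 4 the estimated value is 30 mL.min-1.g-1, with an expected range of 15 mL.min-1.g-1 to 60 mL.min-1.g-1.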

Compound 4, intrinsic clearance in microsomes: 48 mL.min-1.g-1
Compound 4: middle estimate off by 1.6-fold (0.20 log units), on the low side; the measured number falls inside the stated range.
By their numbers in this assay, from the lowest: compounds 2, 3 and 1 (each within the scatter of the next); then compound 4.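

On this aromatic carbon the group does matter in this assay: 1-benzothiophen-5-yl brings a 2.8-fold higher number from compound 3 to compound 4 (0.45 log units; beyond the scatter) and a 3.2-fold higher number from compound 2 to compound 4 (0.51 log units; beyond the scatter) and also a 2.2-fold higher number from compound 1 to compound 4 (0.34 log units; beyond the scatter), all beyond the scatter, whereas exchanges among 2-hydroxyphenyl, pyridin-4-yl and pyridin-3-yl stayed within it. Compound 4 therefore stands apart from compounds 1, 2 and 3, and it is the only one of the four with a fused second ring, a sulfur atom and a substituent lacking both ring nitrogen and hydroxyl. No measurement shown explains the step.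

Which of these differences goes with the higher number remains open, since all of them arrive together in the single change to 1-benzothiophen-5-yl. Plain phenyl, naphthalen-2-yl or indol-5-yl on the same carbon would separate the second ring from the sulfur atom.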